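This account rests on a few compounds, and the source may have more. Where it says the series, first, only, none or still open, it means among the compounds named here.

Of the compounds shown here, three have so far been measured in a functional assay on BMDM cells (Mus musculus, strain C57BL/6) for inhibition, with a stated time of 2 days; a lower number here means a stronger inhibitor, a higher number a weaker inhibitor. Compound 1 `Cc1cc(NC(=O)Cn2cc(-c3ccc(C#N)cc3)nn2)no1` gives 9320 nM, the highest of the three numbers. Compound 2 `Cc1csc(NC(=O)Cn2cc(-c3ccccc3Cl)nn2)n1` gives 1240 nM, and compound 3 `N#Cc1ccc(-c2cn(CC(=O)Nc3nccs3)nn2)cc1` gives 270 nM. Among the compounds with values here, the only measured step that changes a single place is a 35-fold lower number from compound 1 to compound 3 (1.54 log units; beyond the scatter), and it alters the ring on the amide-type nitrogen. Compound 4 `Cc1cc(NC(=O)Cn2cc(-c3ccc(F)cc3)nn2)no1` differs from compound 1 elsewhere: fluoro in place of cyano on an aromatic carbon. Within the data shown here, no measured step touches this part of the structure, so the data give no direct guide to its effect. The expected step is therefore a 1.3-fold higher number from compound 1 to compound 4 (0.11 log units; within the scatter), not beyond the scatter. Compound 4 is estimated at 12000 nM, with a likely range from 4000 nM to 40000 nM.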

Compound 4, half-maximal inhibitory concentration: > 30000 nM
Compound 4 gave a limit, no number; the forecaster's own chance of this, stated with the estimate: 15%; middle value at least 2.5-fold (0.39 log units) away from the limit.
By their numbers in this assay, from the lowest: compound 3; then compound 2; then compound 1. At a limit, above all of these: compound 4.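

Putting fluoro in place of cyano on this aromatic carbon, para to a large group, gives an at least 3.2-fold higher number from compound 1 to compound 4 (0.50 log units; beyond the scatter), so this position does matter for the read-out. With the 5-methyl-1,2-oxazol-3-yl group on the amide-type nitrogen, cyano gives the lower number of the two. Compound 4 gives a limit of the assay, not a number, so the full size of the step stays unknown: the limit of > 30000 nM in this assay, at which 1 of the 4 values shown sits.

Going by these compounds, whether the same change would act alike with the 1,3-thiazol-2-yl group of compound 3 remains open. Also open, on these data alone, is how an amine or a methoxy group would compare at this position.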